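The source may hold more compounds than are shown below. What is called first, only, known or untested is meant among the compounds shown, and "the series" means these compounds.

Measured so far in this assay:
compound 1 `COc1ccc(COc2ccc3c(c2)[C@@H](O)CN(C)C3)cc1` — > 50000 nM
compound 2 `CN1Cc2ccc(OCc3cccnc3)cc2[C@@H](O)C1` — > 50000 nM
compound 3 `COCCOCOc1ccc2c(c1)[C@@H](O)CN(C)C2` — > 50000 nM

In an ADME assay on Vero cells (Chlorocebus sabaeus) for cytotoxicity, read by sulforhodamine B assay, with a stated time of 72 h (on this read-out higher numbers stand for weaker inhibition and lower numbers for stronger inhibition), compound 1 reaches only the limit of the assay, > 50000 nM. Compound 2 likewise sits at a limit, > 50000 nM. Compound 3 sits at a limit as well, > 50000 nM. For the measured compounds named here, compound 1 thus stands, with every value shown, at the limit of > 50000 nM in this assay, at which 3 of the 3 values shown sit; no measured compound gives a number.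

Compound 4 `CN1Cc2ccc(OCc3ccc(-c4ccc(Cl)cc4)cc3)cc2[C@@H](O)C1` differs from compound 1 by 4-chlorophenyl in place of methoxy on an aromatic carbon. Going by the values given here, the only step between measured compounds, a step that the two limits leave unreadable from compound 2 to compound 3, is unreadable and varies a different group, so no measured step bears on the change to compound 4.

With all values at the limit of > 50000 nM in this assay, at which 3 of the 3 values shown sit, the step that the limit leaves unreadable from compound 1 to compound 4 is expected to remain unreadable, most likely another limit. Compound 4 is estimated at 60000 nM, range 15000 nM to 200000 nM.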

Compound 4, half-maximal inhibitory concentration: 21700 nM
Beside the measured number, compound 4's estimate is 2.8-fold (0.44 log units) above it, within the range that was stated.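

In this assay, for the compounds shown here, 4-chlorophenyl in place of methoxy on this aromatic carbon gives an at least 2.3-fold lower number from compound 1 to compound 4 (0.36 log units; beyond the scatter), the first change that the read-out can register. The step is a lower bound, as compound 1 holds only a limit. Compound 4 is the only compound shown that leaves that limit: the limit of > 50000 nM in this assay, at which 3 of the 4 values shown sit.

The compounds shown do not separate the added aromatic ring from its chlorine, as a plain phenyl at this carbon is not among them. Going by these compounds, whether an amine or a carboxylic acid on the same carbon would stay at the limit also remains open.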